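Quinoline for Quinolinone on the Urea Nitrogen

The source may hold more compounds than are shown below. What is called first, only, known or untested is meant among the compounds shown, and "the series" means these compounds.

Of the compounds shown here, three have been measured in an assay on CHO cells for displacement of a labelled ligand from transient receptor potential cation channel subfamily V member 1 (Homo sapiens), read by scintillation counting, with a stated time of 60 min; on this read-out higher numbers stand for weaker inhibition and lower numbers for stronger inhibition. Compound 1 `CN(C)C1(Cc2ccccc2)CCN(c2cc(C(F)(F)F)ccc2CNC(=O)Nc2ccc(CNS(C)(=O)=O)c(F)c2)CC1` gives 16.4 nM, compound 2 `CN(C)C1(Cc2ccccc2)CCN(c2cc(C(F)(F)F)ccc2CNC(=O)NCc2ccc(NS(C)(=O)=O)c(F)c2)CC1` gives 266 nM, and compound 3 `CN(C)C1(Cc2ccccc2)CCN(c2cc(C(F)(F)F)ccc2CNC(=O)Nc2cccc3[nH]c(=O)ccc23)CC1` gives 1.67 nM. Compound 3 thus has the lowest number of the three, and its distance to compound 1, as to compound 2, lies well beyond the usual scatter, so it is the strongest inhibitor here.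

Compound 4 `CN(C)C1(Cc2ccccc2)CCN(c2cc(C(F)(F)F)ccc2CNC(=O)Nc2cccc3ncccc23)CC1` has not been measured. It differs from compound 3 by a group of 10 heavy atoms (9 carbon, 1 nitrogen; one six-membered aromatic ring of carbon only, one six-membered aromatic ring with 1 hetero atom) in place of a group of 11 heavy atoms (9 carbon, 1 nitrogen, 1 oxygen; one six-membered aromatic ring of carbon only, one six-membered aromatic ring with 1 hetero atom), on an amide-type nitrogen. Going by the values given here, no measured pair shows this kind of change, so the expectation rests on the change itself, which removes the hydrogen-bond donor. Compound 4 is expected to remain a strong inhibitor, with a modest weakening from compound 3 that may stay within the scatter, the step being estimated as a 2.7-fold higher number from compound 3 to compound 4 (0.43 log units; beyond the scatter). In this assay compound 4 is estimated at 4.5 nM, between 1.2 nM and 18 nM.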

Compound 4, inhibition constant: 10.8 nM
The estimate for compound 4 lay 2.4-fold (0.38 log units) below the measured number; the range from low to high includes it.
By their numbers in this assay, from the lowest: compound 3; then compounds 4 and 1 (each within the scatter of the next); then compound 2.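

On the amide-type nitrogen, quinolin-5-yl in place of the group in compound 3 gives a 6.5-fold higher number from compound 3 to compound 4 (0.81 log units; beyond the scatter) in this assay, the first single-place step measured here. It shows that the read-out at this position responds to this change, which leaves a group with a hydrogen-bond donor for one with none. Nothing measured here explains the step.

The compounds shown do not separate the loss of the hydrogen-bond donor from the loss of the oxygen. As far as these compounds go, how an amino or hydroxyl group on quinolin-5-yl would read in this assay remains open.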